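This account rests on a few compounds, and the source may have more. Where it says the series, first, only, none or still open, it means among the compounds named here.

Notes on the series. Compound 3 `O=C(COc1cccc2ccccc12)N/N=C/c1cccc(Br)c1` gives 100 ug/mL in an ADME assay on HEL cells (Homo sapiens) for cytotoxicity (on this read-out higher numbers stand for lower toxicity in this test and lower numbers for higher toxicity in this test), the highest of the three numbers measured; compound 1 `Cc1ccc(/C=N/NC(=O)COc2cccc3ccccc23)cc1` gives 20 ug/mL and compound 2 `O=C(COc1cccc2ccccc12)N/N=C/c1ccc([N+](=O)[O-])cc1` gives 20 ug/mL. The measured steps are no change at the digits printed from compound 1 to compound 2 (within the scatter) and a 5.0-fold higher number from compound 1 to compound 3 (0.70 log units; beyond the scatter). Compound 4 `CSc1ccc(/C=N/NC(=O)COc2cccc3ccccc23)cc1` differs from compound 3 by 4-(methylsulfanyl)phenyl in place of 3-bromophenyl on a carbon with a double bond to nitrogen. The step from compound 1 to compound 3 bears on it most directly, as it also exchanges the ring on the carbon with a double bond to nitrogen; the step from compound 1 to compound 2 shows that exchanging the group on that ring left the number unchanged. Compound 4 is therefore expected to fall back toward compounds 1 and 2, with an estimate of 35 ug/mL and a range from 15 ug/mL to 100 ug/mL. The expected step is a 2.9-fold lower number from compound 3 to compound 4 (0.46 log units; beyond the scatter).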

Compound 4, minimum cytotoxic concentration: >= 100 ug/mL
Compound 4: a limit, no number (the forecaster's own chance of this, stated with the estimate: 20%); at least 2.8-fold (0.45 log units) between middle value and limit.
By their numbers in this assay, from the lowest: compounds 1 and 2 (each within the scatter of the next); then compound 3.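

In this assay compound 4 gives a limit, not a number: the limit of >= 100 ug/mL in this assay, at which 1 of the 4 values shown sits. Methylsulfanyl in place of methyl gives an at least 5.0-fold higher number from compound 1 to compound 4 (0.69 log units; beyond the scatter), and methylsulfanyl in place of nitro gives an at least 5.0-fold higher number from compound 2 to compound 4 (0.69 log units; beyond the scatter), so exchanging the group on that ring can move the number, which nitro in place of methyl did not do. 4-(Methylsulfanyl)phenyl in place of 3-bromophenyl gives a number no lower from compound 3 to compound 4 (the limit leaves the size open) and this step cannot be read in size.

From the compounds shown here alone, how far compound 4 lies past its limit stays open. The compounds shown also do not tell whether an amine or a carboxylic acid on that ring would keep the number at this level.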